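The compounds below may be only part of what the source reports. "The series", "measured", "known", "first", "only" and "open" are said of these compounds alone.

Among the measured compounds shown here, compound 2 `COc1ccc2c(c1)C(n1ccccc1=O)=CC(C)(C)O2` gives 5.99 in a functional assay (trachea) with Rattus norvegicus as the target (on this read-out lower numbers stand for lower potency and higher numbers for higher potency (the scale is a negative logarithm)), the second highest of the three numbers measured so far: compound 3 `CC1(C)C=C(n2ccccc2=O)c2cc(C=C(C#N)C#N)ccc2O1` reaches 6.3, while compound 1 `CC1(C)C=C(n2ccccc2=O)c2ccccc2O1` sits at 5.05. Compound 4 `CC1(C)C=C(n2ccccc2=O)c2cc(-c3ccncc3)ccc2O1` differs from compound 2 in one place: pyridin-4-yl in place of methoxy on an aromatic carbon. For the measured compounds named here, three measured steps bear on this change. The step of a number 0.94 log units higher from compound 1 to compound 2 (beyond the scatter) and the step of a number 1.25 log units higher from compound 1 to compound 3 (beyond the scatter) both show that placing a group on this aromatic carbon lifted potency, and the step of a number 0.31 log units higher from compound 2 to compound 3 (beyond the scatter) shows that exchanging methoxy for another group brought a modest further gain. A further modest rise is therefore expected, the step of a number 0.26 log units higher from compound 2 to compound 4 (within the scatter). Compound 4 is estimated at 6.25, with a range from 5.6 to 6.9.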

Compound 4, logarithm of the reciprocal of the active concentration, log(1/C): 6.32
For compound 4 the middle estimate is 0.07 log units below the measured one; the range from low to high includes it.
By their numbers in this assay, from the lowest: compound 1; then compound 2; then compounds 3 and 4 (each within the scatter of the next).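

The step of a number 0.33 log units higher from compound 2 to compound 4 (beyond the scatter) and the step of a number 1.27 log units higher from compound 1 to compound 4 (beyond the scatter) in this assay show that this aromatic carbon can carry a whole six-membered aromatic ring and still gain potency. With the step of a number 0.02 log units higher from compound 3 to compound 4 (within the scatter) between them, pyridin-4-yl and 2,2-dicyanoethenyl cannot be told apart here, so two quite different groups can stand on this carbon at the same level.

Going by these compounds, whether an amine, a carboxylic acid or a plain phenyl ring would do the same stays open. Nothing available explains why these groups give these numbers.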